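The source may report more compounds than this note shows. Statements on the series, on what has been measured and on what is new or still open speak of the compounds shown alone.

Measured so far:
- compound 1, `COc1cc(C(=O)/C=C/c2cc(OC)c(OC)cc2OC)ccc1O`: in a functional assay on MCF7 cells (Homo sapiens) for inhibition, read by MTT assay, with a stated time of 72 h (a lower number here means a stronger inhibitor, a higher number a weaker inhibitor), compound 1 gives 95500 nM
- compound 2, `COc1cc(OC)c(OC)cc1/C=C/C(=O)c1ccc([N+](=O)[O-])cc1`: in this assay compound 2 gives > 150000 nM

The value of compound 2 is a limit of the assay, not a number, as the limit of > 150000 nM in this assay, at which 1 of the 2 values shown sits, records. Compound 3, `COc1cc(OC)c(OC)cc1/C=C/C(=O)c1ccc(F)cc1`, is not yet measured. It differs from compound 2 by one change (fluoro in place of nitro on an aromatic carbon). For the measured compounds named here, no step between measured compounds is known here, so the expected step is taken as small: the change from compound 2 to compound 3 is expected to be an at least 1.2-fold lower number from compound 2 to compound 3 (0.09 log units; that floor lies within the scatter), not beyond the usual scatter. Compound 3 is therefore estimated at 120000 nM, within a range from 40000 nM to 300000 nM.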

Compound 3, half-maximal inhibitory concentration: 30000 nM
Compound 3: the middle estimate sits 4.0-fold (0.60 log units) above what was measured; measured number below the stated range.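

The aromatic carbon para to a large group responds to what it carries: in this assay, fluoro in place of nitro gives an at least 5.0-fold lower number from compound 2 to compound 3 (0.69 log units; beyond the scatter). For the compounds shown here, the earlier compounds offered no pair differing in one place, so this is the first step that can be read, and it lies beyond the usual scatter. Its full size stays unknown because compound 2 has a limit of the assay, not a number: the limit of > 150000 nM in this assay, at which 1 of the 3 values shown sits.

With only nitro and fluoro shown at this carbon, what an amine or a carboxylic acid there would give remains open. As far as these compounds go, whether the same change would act alike on the core of compound 1 is also open.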